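Notes on replacing tert-butoxycarbonyl in the series

The source may report more compounds than this note shows. Statements on the series, on what has been measured and on what is new or still open speak of the compounds shown alone.

Of the compounds shown here, three have been read in a functional assay on isolated protein for agonist activity at Glucose-dependent insulinotropic receptor (Homo sapiens), read by HTRF and cAMP accumulation; on this read-out higher numbers stand for larger maximal responses and lower numbers for smaller maximal responses. Compound 1 `CC(C)(C)OC(=O)N1CCC(O[C@H]2CC[C@H](Oc3ccc(S(C)(=O)=O)c(F)c3)CC2)CC1` gives 106% in this assay. Compound 2 `CC(C)(C)OC(=O)N1CCC(O[C@H]2CC[C@H](Oc3cnc(S(C)(=O)=O)cn3)CC2)CC1` gives 110% in this assay. Compound 3 `CC(C)S(=O)(=O)c1cnc(O[C@H]2CC[C@H](OC3CCN(C(=O)OC(C)(C)C)CC3)CC2)cn1` gives 109% in this assay. Among the measured compounds shown here, the one single-point step among them, isopropyl in place of methyl on a sulfonyl sulfur, gives a number 1 percentage points lower from compound 2 to compound 3 (within the scatter). On the numbers shown, compound 2 holds the highest value of the three, but its gaps to compound 3 and to compound 1 both lie within the scatter, so no ranking is read from them.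

Compound 4 `CC(F)Cc1nc(CN2CCC(O[C@H]3CC[C@H](Oc4cnc(S(C)(=O)=O)cn4)CC3)CC2)no1` differs from compound 2 as follows: (5-(2-fluoropropyl)-1,2,4-oxadiazol-3-yl)methyl in place of tert-butoxycarbonyl on an amine nitrogen in a ring. For the measured compounds named here, no measured step touches the amine nitrogen in a ring, so nothing measured bears directly on this change; the only step available, from compound 2 to compound 3, sits at the sulfonyl sulfur and was within the scatter. All three measured compounds, each carrying tert-butoxycarbonyl, sit close together near full response, and that common level is the only anchor.

Compound 4 is therefore expected to stay near the level of compound 2, with a number 5 percentage points lower from compound 2 to compound 4 (within the scatter) expected to fall within the scatter. The estimate for compound 4 in this assay is 105%, with a range from 88% to 118%.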

Compound 4, largest response reached (Emax), in percent of the reference or control that the assay uses: 97%
The estimate for compound 4 lay 8 percentage points above the measured number; the range from low to high includes it.
By their numbers in this assay, from the lowest: compounds 4, 1, 3 and 2 (each within the scatter of the next, the first and the last beyond it).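

In this assay, among the compounds shown here, (5-(2-fluoropropyl)-1,2,4-oxadiazol-3-yl)methyl in place of tert-butoxycarbonyl on the amine nitrogen in a ring gives a number 13 percentage points lower from compound 2 to compound 4 (beyond the scatter), the first step to lie beyond the scatter, whereas the step at the sulfonyl sulfur, a number 1 percentage points lower from compound 2 to compound 3 (within the scatter), does not. The amine nitrogen in a ring is thus a place where the read-out responds to the group carried, yet tert-butoxycarbonyl is not needed for a large maximal response, since compound 4 still gives 97% with an aromatic ring and no carbonyl in the group on that nitrogen. No measurement among the data shown accounts for the size of this step.

The compounds shown leave open which part of the entering group goes with the lower number: the methyl link, the five-membered aromatic ring or the fluorine of the 2-fluoropropyl chain, which an unfluorinated propyl chain on the same ring or a plain benzyl group on the nitrogen would help to separate. Also open, from the compounds shown here alone, is whether the same replacement gives a step of similar size on the isopropyl sulfone of compound 3 or on the core of compound 1.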